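This account rests on a few compounds, and the source may have more. Where it says the series, first, only, none or still open, it means among the compounds named here.

Measured in a functional assay on the whole organism with Rattus norvegicus as the target; a higher number here means that more compound is needed for the effect, a lower number that less compound is needed:
Compound 1 `CCCc1ccc2nc(N)sc2c1` gives 6 mg/kg.
Compound 2 `N=c1sc2cc(OC(F)(F)F)ccc2n1CCS(N)(=O)=O` gives 6 mg/kg.
Compound 3 `CN(C)S(=O)(=O)CCn1c(=N)sc2cc(OC(F)(F)F)ccc21` gives only a limit, > 10 mg/kg.

Compound 3 thus sits at the limit of > 10 mg/kg in this assay, at which 1 of the 3 values shown sits, not at a number. Among the measured compounds shown here, the single measured step, an at least 1.6-fold higher number from compound 2 to compound 3 (0.22 log units; that floor lies within the scatter), runs into that limit, so its real size is open. Compound 4 `N=c1sc2cc(OC(F)(F)F)ccc2n1CCSc1ccccc1` differs from compound 3 by phenylsulfanyl in place of dimethylsulfamoyl on a saturated chain carbon, two bonds along the chain from an aromatic nitrogen. For the measured compounds named here, no measured step exchanges these groups; the step from compound 2 to compound 3 alters only the substituent on the sulfonyl sulfur and does not carry over. With compound 3 known only as a limit, the expected step of a number no higher from compound 3 to compound 4 (the limit leaves the size open) can be given neither direction nor size from the data. Compound 4 is estimated in this assay at 10 mg/kg, expected between 3 mg/kg and 30 mg/kg, with a real chance that again only a limit is reported.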

Compound 4, dose for half-maximal effect: 4.5 mg/kg
Compound 4: the middle estimate sits 2.2-fold (0.35 log units) above what was measured, and the stated range covers the measured number.
By their numbers in this assay, from the lowest: compounds 4, 1 and 2 (each within the scatter of the next). At a limit, above all of these: compound 3.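

In this assay, among the compounds shown here, replacing dimethylsulfamoyl with phenylsulfanyl on the saturated chain carbon gives an at least 2.2-fold lower number from compound 3 to compound 4 (0.34 log units; beyond the scatter), the only step at this position whose floor lies beyond the scatter. From the compounds shown here alone, compound 3 remains a limit, so the full size of that step is unknown. Replacing sulfamoyl with the same group gives a 1.3-fold lower number from compound 2 to compound 4 (0.12 log units; within the scatter), so a sulfonyl group is not required at this position to retain a value level with that of compound 2.

Going by these compounds, it remains open whether the sulfur or the aromatic ring of phenylsulfanyl matters here. Also open, on these data alone, is how a carboxylic acid, an amine or a longer chain would read at this place.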